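This account rests on a few compounds, and the source may have more. Where it says the series, first, only, none or still open, it means among the compounds named here.

Compounds measured in an ADME assay on HOS cells (Homo sapiens) for cytotoxicity, read by luminescence and ATP content, with a stated time of 48 h; on this read-out higher numbers stand for lower toxicity in this test and lower numbers for higher toxicity in this test
- compound 1 `Nc1c(C(=O)NCc2ccc(F)cc2F)c(=O)n(O)c2ncc(CCCCc3ccccc3)cc12` gives 13000 nM
- compound 2 `Nc1c(C(=O)NCc2ccc(F)cc2F)c(=O)n(O)c2ncc(CCc3ccccc3)cc12` gives 18000 nM
- compound 3 `CN(C)CCCc1cnc2c(c1)c(N)c(C(=O)NCc1ccc(F)cc1F)c(=O)n2O` gives 5000 nM

Compound 3 (5000 nM) has the lowest number of the three, and so it is the most toxic of them in this test. Its steps to the other two lie beyond the scatter, while compound 1 and compound 2 sit within the scatter of each other, as a 1.4-fold higher number from compound 1 to compound 2 (0.14 log units; within the scatter) shows.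

The next compound, compound 4 `CN(C)C(=O)CCc1cnc2c(c1)c(N)c(C(=O)NCc1ccc(F)cc1F)c(=O)n2O`, puts dimethylcarbamoyl in place of (dimethylamino)methyl on a saturated chain carbon, two bonds along the chain from an aromatic carbon. Within the data shown here, two measured steps bear on this site, a 2.6-fold lower number from compound 1 to compound 3 (0.41 log units; beyond the scatter) and a 3.6-fold lower number from compound 2 to compound 3 (0.56 log units; beyond the scatter). Among the measured compounds shown here, both are modest, and both show that the side chain ending in dimethylamino carries the lowest number so far. Compound 4 gives up that ending, so a modest rise in this assay is the likely direction, perhaps back towards the other two compounds. For the measured compounds named here, no measured compound carries dimethylcarbamoyl, however, so this remains a loose expectation and a step within the scatter cannot be ruled out. The expected change is a 2.0-fold higher number from compound 3 to compound 4 (0.30 log units; within the scatter) in size. Compound 4 is estimated at 10000 nM (expected range 4500 nM to 24000 nM).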

Compound 4, half-maximal cytotoxic concentration: > 250000 nM
Compound 4: only a limit was reported; the forecaster's own chance of this, stated with the estimate: 5%; at least 25-fold (1.39 log units) between middle value and limit.
By their numbers in this assay, from the lowest: compound 3; then compounds 1 and 2 (each within the scatter of the next). At a limit, above all of these: compound 4.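

At this position, on a saturated chain carbon, two bonds along the chain from an aromatic carbon, the earlier changes moved the number only modestly or not beyond the scatter, whereas dimethylcarbamoyl in place of (dimethylamino)methyl gives a large step (an at least 50-fold higher number from compound 3 to compound 4 (1.69 log units; beyond the scatter)). The new group also separates compound 4 from both compounds whose chains end in phenyl (an at least 13-fold higher number from compound 2 to compound 4 (1.14 log units; beyond the scatter); an at least 19-fold higher number from compound 1 to compound 4 (1.28 log units; beyond the scatter)), so in this test the side chain can matter far more than the first three compounds suggested. In this assay, the result for compound 4 is a limit, not a number: the limit of > 250000 nM in this assay, at which 1 of the 4 values shown sits.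

From the compounds shown here alone, what remains open is whether the large rise goes with the incoming carbonyl or with the loss of the dimethylamino ending, a question that a carboxylic acid or a methyl ether at the end of the same chain could help to settle. Going by these compounds, it is also open how far the effect carries over to a longer chain ending in dimethylcarbamoyl, or to a cyclic amide such as a morpholine amide in its place.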